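The source may hold more compounds than are shown below. What is called first, only, known or untested is meant among the compounds shown, and "the series" means these compounds.

- Compound 1 `COc1ccc(/C=N/NC(=O)c2cn(C3CC3)c3cc(N/N=C/c4ccc(OC)cc4)c(F)cc3c2=O)cc1`: <= 25000 nM
- Compound 2 `COc1cc(/C=N/NC(=O)c2cn(C3CC3)c3cc(N/N=C/c4cc(OC)c(OC)c(OC)c4)c(F)cc3c2=O)cc(OC)c1OC`: <= 25000 nM
- Compound 3 `O=C(N/N=C/c1ccccc1)c1cn(C2CC2)c2cc(N3CCNCC3)c(F)cc2c1=O`: <= 25000 nM

These entries come from a functional assay on HL-60 cells (Homo sapiens) for antiproliferative activity, read by MTT assay (a higher number here means a weaker inhibitor, a lower number a stronger inhibitor), and each one is a limit of the assay, not a number. The whole picture is the limit of <= 25000 nM in this assay, at which 3 of the 3 values shown sit. For compound 3 the reading is <= 25000 nM, which is only a limit.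

Compound 4 `O=C(N/N=C/c1ccc(F)cc1)c1cn(C2CC2)c2cc(N3CCNCC3)c(F)cc2c1=O` differs from compound 3 on its phenyl group, which becomes 4-fluorophenyl, with fluoro in place of hydrogen on an aromatic carbon. Within the data shown here, no measured pair of compounds shows what a single change of this kind does in this assay. The expected step that the limit leaves unreadable from compound 3 to compound 4 is therefore none beyond the scatter. For compound 4 the estimated value is 18000 nM, with an expected range of 5000 nM to 25000 nM.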

Compound 4, half-maximal inhibitory concentration: <= 25000 nM
Compound 4: a limit, no number; the forecaster's own chance of this, stated with the estimate: 60%; the middle value is on the limit's open side.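

Among these compounds, compound 3 and compound 4 each give only a limit in this assay, so no step between them can be read: the limit of <= 25000 nM in this assay, at which 4 of the 4 values shown sit. What the fluoro group changes, and how strong any of these compounds truly is, stays open.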